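The compounds below may be only part of what the source reports. "The series", "measured", "known", "first", "only" and "open" are said of these compounds alone.

Measured compounds in a functional assay on MCF7 cells (Homo sapiens) for antiproliferative activity; a higher number here means a weaker inhibitor, a lower number a stronger inhibitor:
compound 1 `COc1cccc(Oc2ccc3cc(NC(=O)c4ccc(O)c(CC=C(C)C)c4)c(=O)oc3c2C)c1` gives 62800 nM
compound 2 `COc1ccc(Cc2ccc3cc(NC(=O)c4ccc(O)c(CC=C(C)C)c4)c(=O)oc3c2C)cc1` gives 13300 nM
compound 3 `COc1cccc(Cc2ccc3cc(NC(=O)c4ccc(O)c(CC=C(C)C)c4)c(=O)oc3c2C)c1` gives 19700 nM

Compound 3 stands second highest of the three numbers in this assay. Its nearest neighbour is compound 2, with a 1.5-fold higher number from compound 2 to compound 3 (0.17 log units; within the scatter), a difference within the scatter; its furthest is compound 1, with a 3.2-fold lower number from compound 1 to compound 3 (0.50 log units; beyond the scatter).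

Compound 4 `COc1ccc(Cc2ccc3cc(NC(=O)c4ccc(O)c(CC=C(C)C)c4)c(=O)oc3c2C)cc1OC` differs from compound 3 in one place: methoxy in place of hydrogen on an aromatic carbon.

Among the compounds with values here, of the measured steps, only the one from compound 2 to compound 3 touches the methoxy pattern on the benzyl ring, and it lies within the scatter. The steps of a 4.7-fold lower number from compound 1 to compound 2 (0.67 log units; beyond the scatter) and a 3.2-fold lower number from compound 1 to compound 3 (0.50 log units; beyond the scatter) exchange the linker to that ring and do not bear directly on adding a second methoxy. Within the data shown here, no measured pair shows a second methoxy entering. Among the measured compounds shown here, with the one relevant step within the scatter, no step beyond the scatter is expected in this assay for compound 4, so the expected step is a 1.2-fold lower number from compound 3 to compound 4 (0.09 log units; within the scatter).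

Compound 4 is therefore estimated at 16000 nM in this assay, with a range from 6000 nM to 45000 nM.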

Compound 4, half-maximal inhibitory concentration: 13900 nM
Beside the measured number, compound 4's estimate is 1.2-fold (0.06 log units) above it; low and high end bracket the measured number.
By their numbers in this assay, from the lowest: compounds 2, 4 and 3 (each within the scatter of the next); then compound 1.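

In this assay, within the data shown here, a methoxy entering on the aromatic carbon ortho to a methoxy group gives the first direct reading of a second methoxy, and both steps lie within the scatter: a 1.4-fold lower number from compound 3 to compound 4 (0.15 log units; within the scatter) and a 1.0-fold higher number from compound 2 to compound 4 (0.02 log units; within the scatter). Among these compounds, the 3,4-dimethoxybenzyl group therefore reads the same as either single-methoxy benzyl group, while a 4.5-fold lower number from compound 1 to compound 4 (0.65 log units; beyond the scatter) matches the earlier steps away from 3-methoxyphenoxy and leaves compound 1 apart from compounds 2, 3 and 4. Nothing available accounts for these readings.

Open, on these data alone, is whether an amine or a carboxylic acid on this carbon, or an ethoxy in place of the added methoxy, would give a step beyond the scatter. Also open, as far as these compounds go, is whether a 3,4-dimethoxyphenoxy group would follow the benzyl series or stay with compound 1.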